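The compounds below may be only part of what the source reports. "The series", "measured", "known", "first", "only" and "open" are said of these compounds alone.

Of the compounds shown here, two have been measured in an assay on isolated protein for inhibition of glutathione S-transferase P (Homo sapiens), with a stated time of 10 min; on this read-out lower numbers stand for stronger inhibition and higher numbers for weaker inhibition. Compound 1, with the structure `CN(C)CCNC(=O)CCC(=O)OCCCCCCSc1ccc([N+](=O)[O-])c2nonc12`, gives 540 nM. Compound 2, with the structure `O=C(CCC(=O)N1CCOCC1)OCCCCCCSc1ccc([N+](=O)[O-])c2nonc12`, gives 330 nM. Within the data shown here, the single change between them, a 1.6-fold lower number from compound 1 to compound 2 (0.21 log units; within the scatter), is a step whose size falls within the usual scatter of repeated measurements, so on these two numbers compound 2 and compound 1 cannot be told apart, and neither can be called the stronger inhibitor.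

Compound 3, with the structure `O=C(CCC(=O)N1CCCCC1)OCCCCCCSc1ccc([N+](=O)[O-])c2nonc12`, has not yet been measured. It differs from compound 2 in one place: piperidin-1-yl in place of morpholin-4-yl on a carbonyl carbon. Among the measured compounds shown here, the only measured step that bears on this position is the one from compound 1 to compound 2, and it stayed within the scatter. On that basis the step from compound 2 to compound 3 in this assay is expected to be a 1.1-fold lower number from compound 2 to compound 3 (0.04 log units; within the scatter), a change no larger than the scatter in either direction. Compound 3 is therefore estimated at 300 nM, with a range from 120 nM to 750 nM.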

Compound 3, half-maximal inhibitory concentration: 500 nM
Compound 3: the middle estimate sits 1.7-fold (0.22 log units) below what was measured; measured number inside the range.
By their numbers in this assay, from the lowest: compounds 2, 3 and 1 (each within the scatter of the next).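

In this assay, replacing morpholin-4-yl with piperidin-1-yl on the carbonyl carbon removes the ring oxygen and its one hydrogen-bond acceptor, yet this gives a 1.5-fold higher number from compound 2 to compound 3 (0.18 log units; within the scatter) and leaves the two compounds indistinguishable. Piperidin-1-yl in place of (2-(dimethylamino)ethyl)amino gives a 1.1-fold lower number from compound 1 to compound 3 (0.03 log units; within the scatter) as well, so three different groups at this place now cannot be told apart on these numbers, where earlier only one pair could be compared. No measurement is available that would explain these numbers.

The compounds shown leave open whether any group at this place would move the number beyond the scatter, for example a free carboxylic acid or a primary amine on a longer chain. They also leave open whether a change elsewhere in the molecule would matter more.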